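Swapping a Piperidine Arm for a Bromophenyl Arm

The compounds below may be only part of what the source reports. "The series", "measured", "known", "first", "only" and "open" are said of these compounds alone.

In an assay for inhibition of Tryptophan 2,3-dioxygenase (Homo sapiens), with stated times of 10 min and 60 min, tested at 100 uM (a lower number here means a weaker effect, a higher number a stronger effect of the compound at the concentration tested), compound 1 `Oc1ccc(CNc2cc(C(F)(F)F)cc3[nH]ncc23)cc1` gives 91%, and compound 2 `FC(F)(F)c1cc(NC[C@@H]2CCCCN2)c2cn[nH]c2c1` gives 88%. Within the data shown here, the one measured step, a number 3 percentage points lower from compound 1 to compound 2 (within the scatter), changes the group on a saturated chain carbon bound to a nitrogen on an aromatic ring without moving the reading beyond the scatter. Among the measured compounds shown here, compound 2 therefore stands within the scatter of compound 1, the only other number available. Compound 3 `FC(F)(F)c1cc(NCc2cccc(Br)c2)c2cn[nH]c2c1` differs from compound 2 by 3-bromophenyl in place of piperidin-2-yl on a saturated chain carbon bound to a nitrogen on an aromatic ring. Because the step of a number 3 percentage points lower from compound 1 to compound 2 (within the scatter) at this same place stayed within the scatter, the expected step of a number 1 percentage points lower from compound 2 to compound 3 (within the scatter) is none beyond the scatter. Compound 3 is estimated at 87%, between 72% and 97%.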

Compound 3, a percentage reported as inhibition, at one concentration (the size of the read-out at that concentration, not a potency): 84%
Beside the measured number, compound 3's estimate is 3 percentage points above it; low and high end bracket the measured number.
By their numbers in this assay, from the lowest: compounds 3, 2 and 1 (each within the scatter of the next).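

At this position on a saturated chain carbon bound to a nitrogen on an aromatic ring, 3-bromophenyl replaces piperidin-2-yl (a number 4 percentage points lower from compound 2 to compound 3 (within the scatter)) and 4-hydroxyphenyl (a number 7 percentage points lower from compound 1 to compound 3 (within the scatter)). So a ring of carbon only, with 0 hydrogen-bond donors and 0 hydrogen-bond acceptors, reads alike with both earlier groups. Nothing available explains this closeness.

Going by these compounds, whether a carboxylic acid on the ring or a longer chain at this place would keep the reading stays open. Readings at one concentration also leave any difference in potency among these compounds unresolved.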